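A few compounds are considered here, and "the series" means these few. Any claim that something is new, unique, unknown or untested is made for them only; others in the source may bear on it.

Working notes on the series. Compound 1 `CS(=O)(=O)c1ccc(Cc2n[nH]c(=S)n2/N=C/c2c(F)cccc2Cl)cc1` gives in a functional assay on HeLa cells (Homo sapiens) for cytotoxicity, read by MTT assay, with a stated time of 48 h (on this read-out higher numbers stand for an effect only at larger amounts of compound and lower numbers for an effect already at smaller amounts), a value of 25000 nM. Compound 2 `CS(=O)(=O)c1ccc(Cc2n[nH]c(=S)n2/N=C/c2ccccc2F)cc1` reaches in this assay only the assay limit, > 100000 nM. Compound 3 `CS(=O)(=O)c1ccc(Cc2n[nH]c(=S)n2/N=C/c2cccnc2)cc1` likewise stands in this assay at the limit, > 100000 nM. Compound 3 thus sits, together with compound 2, at the limit of > 100000 nM in this assay, at which 2 of the 3 values shown sit, and only compound 1 carries a number. The measured steps are an at least 4.0-fold higher number from compound 1 to compound 2 (0.60 log units; beyond the scatter) and an at least 4.0-fold higher number from compound 1 to compound 3 (0.60 log units; beyond the scatter); the step that the two limits leave unreadable from compound 2 to compound 3 cannot be sized. Compound 4 `CS(=O)(=O)c1ccc(Cc2n[nH]c(=S)n2/N=C/c2cccs2)cc1` differs from compound 3 by thiophen-2-yl in place of pyridin-3-yl on a carbon with a double bond to nitrogen. Of the known steps, an at least 4.0-fold higher number from compound 1 to compound 3 (0.60 log units; beyond the scatter) and a step that the two limits leave unreadable from compound 2 to compound 3 concern the same carbon with a double bond to nitrogen, but both end at a limit, so they do not show what an exchange between two heteroaryl groups does. Every replacement of the 2-chloro-6-fluorophenyl seen so far has pushed the number to the limit, so compound 4 is expected to stay near it, with an expected step of an at least 1.1-fold lower number from compound 3 to compound 4 (0.04 log units; that floor lies within the scatter). For compound 4 the estimate in this assay is 90000 nM, within 30000 nM to 250000 nM.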

Compound 4, half-maximal effective concentration: 100000 nM
The estimate for compound 4 lay 1.1-fold (0.05 log units) below the measured number, within the range that was stated.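

Thiophen-2-yl in place of 2-chloro-6-fluorophenyl on a carbon with a double bond to nitrogen gives in this assay a step of readable size (a 4.0-fold higher number from compound 1 to compound 4 (0.60 log units; beyond the scatter)). The other two new steps (a number no higher from compound 3 to compound 4 (the limit leaves the size open) and a number no higher from compound 2 to compound 4 (the limit leaves the size open)) cannot be read for size, so the five-membered aromatic ring with sulfur cannot be ranked against the 2-fluorophenyl or pyridin-3-yl groups. Compound 4 therefore adds a third group that gives no number lower than that of compound 1, while its own number gives no separation from the compounds held at the limit: the limit of > 100000 nM in this assay, at which 2 of the 4 values shown sit.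

The compounds shown leave open whether a chlorophenyl or dichlorophenyl group at this carbon gives a number like that of compound 1. Also open, as far as these compounds go, is what an amine or a carboxylic acid on the aromatic ring does.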